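Replacing methoxymethyl with 4-cyanophenyl in compound 3

The source may report more compounds than this note shows. Statements on the series, on what has been measured and on what is new or still open speak of the compounds shown alone.

Values in a physicochemical assay for solubility, at pH 6.8; a lower number here means a less soluble compound, a higher number a more soluble compound:
compound 1 `O=C(NCc1cccnc1)Nc1ccc(CNC(=O)c2ccc(CN3CCNCC3)cc2)cc1`: > 1000000 nM, a limit
compound 2 `C[C@H](NC(=O)CC(F)(F)F)c1ccc(NC(=O)[C@H]2C[C@@H]2c2cccnc2)cc1`: 41000 nM
compound 3 `COCC(=O)N[C@@H](C)c1ccc(NC(=O)[C@H]2C[C@@H]2c2cccnc2)cc1`: 520000 nM

Compound 3 holds the higher of the two actual numbers, and compound 2 is its nearest neighbour. The entry for compound 1 is a limit and is not ranked here.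

Compound 4 `C[C@H](NC(=O)c1ccc(C#N)cc1)c1ccc(NC(=O)[C@H]2C[C@@H]2c2cccnc2)cc1` is the next case, with 4-cyanophenyl in place of methoxymethyl on a carbonyl carbon.

Among the measured compounds shown here, only one measured step bears on this change: a 13-fold higher number from compound 2 to compound 3 (1.10 log units; beyond the scatter). That step also alters the group carried on the carbonyl, and it is large, though a single step is thin support. With compound 3 at 520000 nM, a large move to a lower number, beyond the scatter, is expected in this assay. The expected size is a 26-fold lower number from compound 3 to compound 4 (1.41 log units; beyond the scatter). The estimate for compound 4 is 20000 nM, with an expected range of 2500 nM to 150000 nM.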

Compound 4, solubility: 175000 nM
Beside the measured number, compound 4's estimate is 8.8-fold (0.94 log units) below it, outside the stated range (above it).
By their numbers in this assay, from the lowest: compound 2; then compound 4; then compound 3. At a limit, above all of these: compound 1.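

In this assay, putting 4-cyanophenyl in place of methoxymethyl on this carbonyl carbon gives a modest fall (  a 3.0-fold lower number from compound 3 to compound 4 (0.47 log units; beyond the scatter)), so a group with a six-membered aromatic ring keeps the number well clear of the one carried by the 2,2,2-trifluoroethyl amide (  a 4.3-fold higher number from compound 2 to compound 4 (0.63 log units; beyond the scatter)). The three groups on this carbonyl carbon now give an order, with 2,2,2-trifluoroethyl lowest, 4-cyanophenyl in the middle and methoxymethyl highest, and each gap lies beyond the scatter. No measurement shown here bears on the cause of these steps.

From the compounds shown here alone, it remains open whether the nitrile contributes anything, as a plain phenyl on this carbonyl carbon would show. Also open, going by these compounds, is whether an aminomethyl group or a carboxylic acid in this place would take the number past that of compound 3.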